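This account rests on a few compounds, and the source may have more. Where it says the series, first, only, none or still open, it means among the compounds named here.

Compound 1 `O=C(/C=C/c1cccc(NS(=O)(=O)c2ccccc2Cl)c1)c1nc2ccccc2[nH]1` gives 4280 nM in a functional assay on MCF7 cells (Homo sapiens) for antiproliferative activity, read by MTT assay, with a stated time of 48 h; a lower number here means a stronger inhibitor, a higher number a weaker inhibitor. Compound 2 `O=C(/C=C/c1cccc(NS(=O)(=O)c2ccc(Cl)cc2)c1)c1nc2ccccc2[nH]1` gives 3820 nM in this assay.

For the measured compounds named here, compound 2 holds the lower of the two numbers measured so far, but the step of a 1.1-fold lower number from compound 1 to compound 2 (0.05 log units; within the scatter) is within the scatter, so the two compounds cannot be told apart on these data. Compound 3 `Cc1ccccc1S(=O)(=O)Nc1cccc(/C=C/C(=O)c2nc3ccccc3[nH]2)c1` differs from compound 2 by 2-methylphenyl in place of 4-chlorophenyl on a sulfonyl sulfur. Going by the values given here, the only measured step that touches this group is the one from compound 1 to compound 2, where moving the chlorine around the same ring gave no change beyond the scatter. Among the compounds with values here, no measured step exchanges chlorine for methyl on this ring, so the data give no direction for the new change. Compound 3 is therefore expected to stay near compound 2, with a step of a 1.0-fold higher number from compound 2 to compound 3 (0.02 log units; within the scatter) in this assay. The estimate for compound 3 is 4000 nM, with a range from 1500 nM to 11000 nM.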

Compound 3, half-maximal inhibitory concentration: 4130 nM
Compound 3: the middle estimate sits 1.0-fold (0.01 log units) below what was measured; low and high end bracket the measured number.
By their numbers in this assay, from the lowest: compounds 2, 3 and 1 (each within the scatter of the next).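

In this assay, the group on the sulfonyl sulfur now changes in kind and not only in place: methyl in place of chloro on an aromatic carbon gives a 1.0-fold lower number from compound 1 to compound 3 (0.02 log units; within the scatter) and 2-methylphenyl in place of 4-chlorophenyl gives a 1.1-fold higher number from compound 2 to compound 3 (0.03 log units; within the scatter) in the same assay. Neither change leaves the scatter, so compound 1, compound 2 and compound 3 cannot be told apart on these data, whichever of the three groups sits on the sulfonyl sulfur. Nothing available accounts for this result.

The compounds shown leave open whether this holds beyond a chlorine or a methyl on the ring. An amine or a carboxylic acid on the ring, or a longer chain in its place on the sulfonyl sulfur, could still move the number.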